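The source may hold more compounds than are shown below. What is called first, only, known or untested is meant among the compounds shown, and "the series" means these compounds.

Compound 1: `COc1cc(-c2cnn3cc(OC)c(C4CCCC4)nc23)ccn1` — 7%
Compound 2: `COc1cn2ncc(-c3ccnc(OC(C)C)c3)c2nc1-c1cnn(C)c1` — 50%

Of the compounds shown here, two have been measured in an ADME assay on microsomes from liver (Rattus norvegicus) for metabolic stability, with a stated time of 60 min, tested at 1 uM; on this read-out higher numbers stand for a more stable compound and lower numbers for a less stable compound. Compound 1 gives 7%, the lowest of the two numbers; the nearest other compound, compound 2, gives 50%, a gap that lies beyond the usual scatter of this assay. Within the data shown here, the two differ in more than one place, so no single counted step connects them.

Compound 3 is `COc1cc(-c2cnn3cc(OC)c([C@H]4COC(C)(C)C4)nc23)ccn1`; it has not yet been measured in this assay. Compared with compound 1 it differs in one place: a group of 7 heavy atoms (6 carbon, 1 oxygen; one five-membered non-aromatic ring with 1 hetero atom) in place of a group of 5 heavy atoms (5 carbon; one five-membered non-aromatic ring of carbon only), on an aromatic carbon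

Whether a five-membered non-aromatic ring with one hetero atom in place of a ring of carbon only shifts the stability cannot be read from the measured pair, as compound 2 departs from compound 1 in several places at once. Compound 1 leaves ample room for a rise, and a moderate rise is what is expected here, so the step of a number 21 percentage points higher from compound 1 to compound 3 (beyond the scatter) is estimated as an increase beyond the scatter. For compound 3 the estimated value is 28%, with a range from 10% to 55%.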

Compound 3, percent of the compound remaining: 30%
Compound 3: middle estimate off by 2 percentage points, on the low side; low and high end bracket the measured number.
By their numbers in this assay, from the lowest: compound 1; then compound 3; then compound 2.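

In this assay, putting the five-membered non-aromatic ring with 1 hetero atom in place of cyclopentyl gives a number 23 percentage points higher from compound 1 to compound 3 (beyond the scatter). Among these compounds, this is the first comparison here in which only one place changes, and it shows that the group on this aromatic carbon, next to the ring nitrogen, matters for the read-out while the rest of the molecule stays the same. The gain is modest, however: the change adds one hydrogen-bond acceptor and one defined stereocentre, yet compound 3 at 30% still loses much of its material by the end of the incubation, and nothing measured here explains the rise.

The entering group brings in the ring oxygen and extra carbon atoms at the same time, so these compounds cannot show which of the two goes with the higher number, or whether the arrangement at the stereocentre plays a part. From the compounds shown here alone, how a morpholine ring or a simple amine would behave on this same carbon also remains open.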